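Fluoro for chloro on the aryl of compound 1

A few compounds are considered here, and "the series" means these few. Any claim that something is new, unique, unknown or untested is made for them only; others in the source may bear on it.

Compound 1 `C/C(=C\CC/C(C)=C/CC[C@@H]1[C@@]2(C)CCC(=O)C(C)(C)[C@H]2CC[C@@]1(C)O)CC/C=C(\C)C(=O)OCc1cn(-c2ccccc2Cl)nn1` is known in a functional assay on A549 cells (Homo sapiens) for antiproliferative activity, read by MTT assay, with a stated time of 48 h (a higher number here means a weaker inhibitor, a lower number a stronger inhibitor), only as a limit: compound 1 gives > 150000 nM. Compound 2 `C/C(=C\CC/C(C)=C/CC[C@@H]1[C@@]2(C)CCC(=O)C(C)(C)[C@H]2CC[C@@]1(C)O)CC/C=C(\C)C(=O)OCc1cn(-c2cccc(Cl)c2)nn1` gives 147000 nM in this assay. Compound 3 `C/C(=C\CC/C(C)=C/CC[C@@H]1[C@@]2(C)CCC(=O)C(C)(C)[C@H]2CC[C@@]1(C)O)CC/C=C(\C)C(=O)OCc1cn(-c2cccc(C(F)(F)F)c2)nn1` again returns only a limit, > 150000 nM. The measured steps run an at least 1.0-fold lower number from compound 1 to compound 2 (0.00 log units; that floor lies within the scatter) and an at least 1.0-fold higher number from compound 2 to compound 3 (0.00 log units; that floor lies within the scatter), while a step that the two limits leave unreadable from compound 1 to compound 3; (the limit of > 150000 nM in this assay, at which 2 of the 3 values shown sit). Compound 4 `C/C(=C\CC/C(C)=C/CC[C@@H]1[C@@]2(C)CCC(=O)C(C)(C)[C@H]2CC[C@@]1(C)O)CC/C=C(\C)C(=O)OCc1cn(-c2ccccc2F)nn1` differs from compound 1 as fluoro in place of chloro on an aromatic carbon. Within the data shown here, no measured step exchanges these two halogens, and every change made so far on the aryl ring stays within the scatter or at the limit, so in this assay no step beyond the scatter is expected, with a number no higher from compound 1 to compound 4 (the limit leaves the size open). Compound 4 is therefore estimated at 150000 nM, in the range 80000 nM to 300000 nM, most likely reported again only as a limit.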

Compound 4, half-maximal inhibitory concentration: > 150000 nM
Compound 4 was reported as a limit; the forecaster's own chance of this, stated with the estimate: 70%; the middle value lies on the limit itself.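

Among these compounds, compound 4 is a limit in this assay, as compound 1 is, so fluoro in place of chloro on this aromatic carbon, ortho to a large group, gives no readable change: the limit of > 150000 nM in this assay, at which 3 of the 4 values shown sit. Against the only exact value, the result is an at least 1.0-fold higher number from compound 2 to compound 4 (0.00 log units; that floor lies within the scatter). The steps between compounds reported only as limits cannot be read.

Open, from the compounds shown here alone, is whether any aryl substituent brings a value clear of the limit. An amine or a carboxylic acid on this ring would test that.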